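The compounds below may be only part of what the source reports. "The series", "measured", "known", "first", "only" and "open" are said of these compounds alone.

Compound 1 `Cc1cc2nccnc2cc1Nc1ncc2c(n1)n(C1CCOCC1)c(=O)n2C` gives 6.9 mL.min-1.g-1 in an ADME assay on microsomes from liver (Homo sapiens) for metabolic stability (on this read-out higher numbers stand for fast clearance and lower numbers for slow clearance), the lower of the two numbers available. Compound 2 `Cc1cc2nnccc2cc1Nc1ncc2c(n1)n(C1CCN(C)CC1)c(=O)n2C` stands at 17 mL.min-1.g-1, a gap beyond the scatter. Compound 3 `Cc1cc2nccnc2cc1Nc1ncc2c(n1)n(C1CCN(C)CC1)c(=O)n2C` has not yet been measured. It differs from compound 1 in one place: 1-methylpiperidin-4-yl in place of oxan-4-yl on an aromatic nitrogen. For the measured compounds named here, no measured pair isolates this change, but compound 2, at 17 mL.min-1.g-1, also carries 1-methylpiperidin-4-yl, so a rise is expected. The expected size is a 2.2-fold higher number from compound 1 to compound 3 (0.34 log units; beyond the scatter). For compound 3 the estimate is 15 mL.min-1.g-1, with an expected range of 7.5 mL.min-1.g-1 to 30 mL.min-1.g-1.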

Compound 3, intrinsic clearance in microsomes in the Homo sapiens assay: < 4 mL.min-1.g-1
Compound 3: only a limit was reported; the forecaster's own chance of this, stated with the estimate: 3%; at least 3.7-fold (0.57 log units) between middle value and limit.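

In the Homo sapiens assay, 1-methylpiperidin-4-yl in place of oxan-4-yl on an aromatic nitrogen gives an at least 1.7-fold lower number from compound 1 to compound 3 (0.23 log units; that floor lies within the scatter), and compound 3 reads < 4 mL.min-1.g-1, which is a limit of the assay and not a number, so this single-place change shows no rise in clearance. In a physicochemical assay for lipophilicity, read by HPLC, using the shake flask method, measured as octanol-water partition, at pH 7.4 (on this read-out lower numbers stand for lower lipophilicity and higher numbers for higher lipophilicity), compound 1 reads 2.2 and compound 3 reads 1.2. The same change gives, in the physicochemical assay, a number 1.00 log units lower from compound 1 to compound 3 (beyond the scatter).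

One pair cannot tell whether the clearance and the distribution coefficient move together. Going by these compounds, how an open-chain amine or a morpholine would read at this position stays open.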